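A few compounds are considered here, and "the series" means these few. Any claim that something is new, unique, unknown or untested is made for them only; others in the source may bear on it.

In a functional assay (trachea) with Cavia porcellus as the target (on this read-out higher numbers stand for weaker inhibition and lower numbers for stronger inhibition), two compounds that share one core have been measured so far. Compound 1 (`O=c1c2ccccc2c(-c2cccnc2)nn1CC1CCCCC1`) gives 209 nM, while compound 2 (`O=c1c2ccccc2c(-c2cccnc2)nn1CCSc1ncccn1`) gives 11000 nM, the higher of the two numbers and therefore the weaker inhibition. Among the compounds with values here, the only measured step is a 53-fold higher number from compound 1 to compound 2 (1.72 log units; beyond the scatter), a large change beyond the scatter, made by putting ((pyrimidin-2-yl)sulfanyl)methyl in place of cyclohexyl.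

Compound 3 (`CC(C)NC(=O)CCCn1nc(-c2cccnc2)c2ccccc2c1=O`) has not yet been measured. It carries (isopropylcarbamoyl)methyl in place of (pyrimidin-2-yl)sulfanyl on a saturated chain carbon, two bonds along the chain from an aromatic nitrogen. Within the data shown here, no measured compound carries this amide group, so the evidence is thin. Among the measured compounds shown here, the one relevant guide is the step to compound 2, a 53-fold higher number from compound 1 to compound 2 (1.72 log units; beyond the scatter), which shows that swapping groups on this chain can shift this assay strongly. Compound 2 sits at the high end of the numbers, so a move back toward lower numbers seems more likely than a further rise. The estimated change is moderate, expected as a 4.4-fold lower number from compound 2 to compound 3 (0.64 log units; beyond the scatter). Compound 3 is expected near 2500 nM, with an estimated range from 400 nM to 12000 nM.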

Compound 3, half-maximal inhibitory concentration: 64600 nM
Compound 3: the middle estimate sits 26-fold (1.41 log units) below what was measured; measured number above the stated range.
By their numbers in this assay, from the lowest: compound 1; then compound 2; then compound 3.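

In this assay, putting (isopropylcarbamoyl)methyl in place of (pyrimidin-2-yl)sulfanyl gives a 5.9-fold higher number from compound 2 to compound 3 (0.77 log units; beyond the scatter) and so shows that an amide-bearing group with no ring does not bring the number back towards that of compound 1. Set directly against cyclohexyl on a saturated chain carbon bound to an aromatic nitrogen, 2-(isopropylcarbamoyl)ethyl gives a 310-fold higher number from compound 1 to compound 3 (2.49 log units; beyond the scatter) and thereby widens the spread at this position, where two quite different replacements have now both raised the number and compound 1 keeps the lowest number of the three. No measurement available here explains these shifts.

The compounds shown leave open whether the low number of compound 1 depends on a ring as such or simply on a group built only of carbon and hydrogen, a question that a phenyl ring or a plain hexyl chain at the same place could help to settle. From the compounds shown here alone, it also remains open which part of the 2-(isopropylcarbamoyl)ethyl group goes with the high number, and a carboxylic acid or an unsubstituted primary amide at the end of the same chain would test this.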